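This account rests on a few compounds, and the source may have more. Where it says the series, first, only, none or still open, it means among the compounds named here.

Compound 1 `C#CCN(CCCCOc1ccc2ccc(=O)oc2c1)Cc1cccc(OC)c1` and compound 2 `C#CCN(CCCCOc1ccc2ccc(=O)oc2c1)Cc1cccc(F)c1` share one core and differ only in the group on the saturated chain carbon bound to the amine nitrogen. In an ADME assay on isolated protein for inhibition of Amine oxidase [flavin-containing] A (Homo sapiens), read by fluorescence and Amplex Red, with stated times of 15 min and 20 min (a higher number here means a weaker inhibitor, a lower number a stronger inhibitor), compound 1 gives 78600 nM. In the same assay compound 2 gives 69200 nM, the lower of the two numbers, yet the step of a 1.1-fold lower number from compound 1 to compound 2 (0.06 log units; within the scatter) lies within the scatter. Compound 3 `C#CCN(CCCCOc1ccc2ccc(=O)oc2c1)Cc1ccc(C)cc1` alters that same group again: 4-methylphenyl in place of 3-fluorophenyl on a saturated chain carbon bound to an amine nitrogen. Within the data shown here, since the only measured step at this place stayed within the scatter, no change beyond the scatter is expected, and the expected step is a 1.0-fold higher number from compound 2 to compound 3 (0.00 log units; within the scatter). Compound 3 is therefore estimated at 70000 nM, ranging from 35000 nM to 140000 nM.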

Compound 3, half-maximal inhibitory concentration: 94500 nM
Beside the measured number, compound 3's estimate is 1.4-fold (0.13 log units) below it; the range from low to high includes it.
By their numbers in this assay, from the lowest: compounds 2, 1 and 3 (each within the scatter of the next).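

In this assay, 4-methylphenyl in place of 3-fluorophenyl gives a 1.4-fold higher number from compound 2 to compound 3 (0.14 log units; within the scatter), and 4-methylphenyl in place of 3-methoxyphenyl gives a 1.2-fold higher number from compound 1 to compound 3 (0.08 log units; within the scatter). On a saturated chain carbon bound to an amine nitrogen, these three substituted phenyl groups therefore all lie within the scatter of one another, even with a different group at a different ring position. No evidence is available to explain this result. On these data alone, whether a carboxylic acid or an amine on the phenyl ring, or a cyclohexyl group replacing that ring, would shift the number beyond the scatter remains open.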